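The source may hold more compounds than are shown below. What is called first, only, known or untested is meant among the compounds shown, and "the series" means these compounds.

The series rests on three measured compounds and one still to be tested. Compound 1 `CCc1ccccc1NS(=O)(=O)c1cccc(NC(=O)NCCCCl)c1` gives 96000 nM in a functional assay on HT-29 cells (Homo sapiens) for cytotoxicity, read by sulforhodamine B assay, with a stated time of 48 h; on this read-out lower numbers stand for stronger inhibition and higher numbers for weaker inhibition. Compound 2 `CCCc1ccccc1NS(=O)(=O)c1cccc(NC(=O)NCCCCl)c1` gives 15000 nM, which places it second highest of the three numbers; the step of a 6.4-fold lower number from compound 1 to compound 2 (0.81 log units; beyond the scatter) separates it from compound 1. For the measured compounds named here, compound 3 `CCCc1ccccc1OS(=O)(=O)c1ccc(NC(=O)NCC)cc1` gives 2400 nM, and compound 2 stands beyond the scatter above it, though no single step links the two, as their structures differ in more than one place.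

Compound 4 `CCCc1ccccc1NS(=O)(=O)c1cccc(NC(=O)NCC)c1` is the next compound, and the change is hydrogen in place of chloromethyl on a saturated chain carbon, two bonds along the chain from an amide-type nitrogen. Going by the values given here, none of the measured steps touches this position: the step from compound 1 to compound 2 concerns the alkyl chain on the other aryl ring. Among the compounds with values here, the only pointer is that compound 3, which also carries the ethylamino end, sits lower, but it differs from compound 4 elsewhere as well. The writer therefore expects a step of a 1.5-fold lower number from compound 2 to compound 4 (0.18 log units; within the scatter) of no more than modest size, if any beyond the scatter, and estimates for compound 4 a value of 10000 nM, with a range from 3000 nM to 40000 nM.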

Compound 4, half-maximal inhibitory concentration: 41000 nM
Estimate against measurement, compound 4: 4.1-fold (0.61 log units) below; measured number outside the range, above it.
By their numbers in this assay, from the lowest: compound 3; then compound 2; then compound 4; then compound 1.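

In this assay, for the compounds shown here, the change from (3-chloropropyl)amino to ethylamino gives a 2.7-fold higher number from compound 2 to compound 4 (0.44 log units; beyond the scatter), so the position on the saturated chain, which no earlier step touched, does affect the read-out. Here the compound that keeps the chloromethyl has the lower number, and the loss of those two heavy atoms is enough to produce a step beyond the scatter. No measured evidence bears on what lies behind this step.

The single step changes chain length and removes the chlorine together, so the compounds shown do not separate the two; a plain propyl chain or a 2-chloroethyl end would speak to that. Going by these compounds, how other ends at this position, such as a bromine, a hydroxyl or an amine, would read also remains open.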